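Ethynyl for furan-3-yl on the shared core: compound 4

The source may hold more compounds than are shown below. What is called first, only, known or untested is meant among the compounds shown, and "the series" means these compounds.

Compound 3 `Cc1ncnc2c1c(-c1ccoc1)cn2[C@@H]1O[C@H](CO)[C@@H](O)[C@H]1O` stands at a limit in a functional assay on CCRF-CEM cells (Homo sapiens), read by MTT assay, with a stated time of 72 h (a higher number here means a weaker inhibitor, a lower number a stronger inhibitor), giving > 20000 nM. It sits at the limit of > 20000 nM in this assay, at which 2 of the 3 values shown sit, rather than at a number. Compound 1 `C#Cc1cn([C@@H]2O[C@H](CO)[C@@H](O)[C@H]2O)c2ncnc(OC)c12` likewise reports only a limit there, > 20000 nM. Among the measured compounds shown here, compound 2 `C#Cc1cn([C@@H]2O[C@H](CO)[C@@H](O)[C@H]2O)c2ncnc(N(C)C)c12` gives 90 nM in this assay, and the sole measured step is an at least 220-fold lower number from compound 1 to compound 2 (2.34 log units; beyond the scatter). Compound 4 `C#Cc1cn([C@@H]2O[C@H](CO)[C@@H](O)[C@H]2O)c2ncnc(C)c12` differs from compound 3 by ethynyl in place of furan-3-yl on an aromatic carbon. For the measured compounds named here, that measured step concerns another group, so no measured step bears on this exchange. Compound 4 carries the ethynyl group shared with compound 1 and compound 2, whose values fall on both sides, so the ethynyl group by itself fixes nothing. The expected value for compound 4 in this assay is 2000 nM, from 100 nM to 20000 nM. This corresponds to an expected step of an at least 10-fold lower number from compound 3 to compound 4 (1.00 log units; beyond the scatter).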

Compound 4, half-maximal inhibitory concentration: 5600 nM
Beside the measured number, compound 4's estimate is 2.8-fold (0.45 log units) below it, within the range that was stated.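

Ethynyl in place of furan-3-yl, on the aromatic carbon two ring bonds from the ring nitrogen, is the first measured exchange at this place, with an at least 3.5-fold lower number from compound 3 to compound 4 (0.55 log units; beyond the scatter). With ethynyl held fixed, the second varied group on the shared core now has a measured middle: methyl gives an at least 3.5-fold lower number from compound 1 to compound 4 (0.55 log units; beyond the scatter), while methyl in place of dimethylamino gives a 62-fold higher number from compound 2 to compound 4 (1.79 log units; beyond the scatter). The steps from compound 1 and compound 3 start from a limit and are bounds only: the limit of > 20000 nM in this assay, at which 2 of the 4 values shown sit.

From the compounds shown here alone, whether an amine such as methylamino or a longer chain such as ethyl at the methyl place comes nearer to dimethylamino stays open. Going by these compounds, how a nitrile at the ethynyl place would compare is also open.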